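This account rests on a few compounds, and the source may have more. Where it says the series, first, only, none or still open, it means among the compounds named here.

Measured compounds in the series:

Compound 1 `CC1=CC[C@H](C(C)(C)NC(=S)N/N=C/c2ccccc2O)CC1` in a functional assay on UACC-62 cells (Homo sapiens) for inhibition, read by sulforhodamine B assay, with a stated time of 48 h (a higher number here means a weaker inhibitor of growth, a lower number a stronger inhibitor of growth), gives 2800 nM.
Compound 2 `CC1=CC[C@H](C(C)(C)NC(=S)N/N=C/c2ccc(N(C)C)cc2)CC1` in this assay gives 45100 nM.
Compound 3 `CC1=CC[C@H](C(C)(C)NC(=S)N/N=C/c2ccc(F)cc2)CC1` in this assay gives > 100000 nM, which is a limit of the assay and not a number.

Compound 3 therefore has no fixed place among the numbers shown: it sits at the limit of > 100000 nM in this assay, at which 1 of the 3 values shown sits, and only its steps from the other two compounds give it any position. Both measured steps end at compound 3. The step of an at least 35-fold higher number from compound 1 to compound 3 (1.55 log units; beyond the scatter) and the step of an at least 2.2-fold higher number from compound 2 to compound 3 (0.34 log units; beyond the scatter) run the same way, towards the limit, so compound 3 is the weakest of the three in this assay.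

Compound 4 `CC1=CC[C@H](C(C)(C)NC(=S)N/N=C/c2ccc(Cl)cc2)CC1` is not yet measured. It differs from compound 3 in one place: chloro in place of fluoro on an aromatic carbon. Within the data shown here, no measured pair carries this change, and neither step involves chloro, so the two steps set only the starting point, not the direction. Since compound 3 already stands at the limit, any number for compound 4 can only be read if the change brings growth inhibition back into the measured range. The expected step of a number no higher from compound 3 to compound 4 (the limit leaves the size open) is none beyond the scatter. Compound 4 is estimated at 100000 nM, with a range from 30000 nM to 300000 nM, and most likely reported as a limit again.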

Compound 4, concentration for 50% growth inhibition: 11200 nM
Compound 4: middle estimate off by 8.9-fold (0.95 log units), on the high side; the measured number lies below the stated range.
By their numbers in this assay, from the lowest: compound 1; then compound 4; then compound 2. At a limit, above all of these: compound 3.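

Swapping 4-fluorophenyl for 4-chlorophenyl shows that this place, para to a large group, is not closed to growth inhibition in this assay: the change gives an at least 8.9-fold lower number from compound 3 to compound 4 (0.95 log units; beyond the scatter). Compound 3 stands at a limit and not a number, so that step fixes only a minimum size: the limit of > 100000 nM in this assay, at which 1 of the 4 values shown sits. With chloro in place of dimethylamino at the same place giving a 4.0-fold lower number from compound 2 to compound 4 (0.60 log units; beyond the scatter), chloro is the best of the three groups shown there, yet 4-chlorophenyl in place of 2-hydroxyphenyl still gives a 4.0-fold higher number from compound 1 to compound 4 (0.60 log units; beyond the scatter), so no group at this place reaches the 2-hydroxyphenyl compound.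

Going by these compounds, whether bromo or methoxy at this place would carry the gain from fluoro to chloro further, or fall back towards the limit, stays open. Also open is whether a hydroxy group and a chloro group on one ring would add together, since the compounds shown carry each group only on its own, and with only four compounds no trend across the halogens can be claimed from this single pair.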